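This account rests on a few compounds, and the source may have more. Where it says the series, first, only, none or still open, it means among the compounds named here.

In an assay on cells for displacement of a labelled ligand from Neuronal acetylcholine receptor; alpha3/beta4 (Homo sapiens) (a higher number here means a weaker inhibitor, a lower number a stronger inhibitor), compound 2 `O=C(Nc1cccc(F)c1)c1cncc(N2CC3CC(C2)N3)c1` gives 28 nM, the lowest of the three numbers recorded. Compound 3 `O=C(c1cncc(N2CC3CC(C2)N3)c1)N1CCCc2ccccc21` gives 62 nM in this assay, and compound 1 `O=C(Nc1ccc(I)cc1)c1cncc(N2CC3CC(C2)N3)c1` gives 103 nM. Among the compounds with values here, the only step between measured compounds that differ in one place is a 3.7-fold lower number from compound 1 to compound 2 (0.57 log units; beyond the scatter), which shows that exchanging the aryl group on the amide-type nitrogen can shift the number by a modest amount.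

Compound 4 `O=C(Nc1ccccc1F)c1cncc(N2CC3CC(C2)N3)c1` has not yet been measured. It differs from compound 2 in one place: 2-fluorophenyl in place of 3-fluorophenyl on an amide-type nitrogen. Within the data shown here, no measured step exchanges one fluorophenyl for another on that nitrogen, so the step from compound 1 to compound 2 bears on it only as a guide to the scale of change that this position can produce. With the same atoms joined differently, the expected step is small, likely within the scatter or a slight rise.

Compound 4 is therefore expected to give about 40 nM in this assay, with a range from 15 nM to 110 nM, corresponding to an estimated step of a 1.4-fold higher number from compound 2 to compound 4 (0.15 log units; within the scatter).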

Compound 4, inhibition constant: 102 nM
For compound 4 the middle estimate is 2.6-fold (0.41 log units) below the measured one; the range from low to high includes it.
By their numbers in this assay, from the lowest: compound 2; then compounds 3, 4 and 1 (each within the scatter of the next).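

In this assay, moving the fluorine on the phenyl ring, with the same atoms joined differently, gives a 3.6-fold higher number from compound 2 to compound 4 (0.56 log units; beyond the scatter), so the number at this nitrogen depends on where the fluorine sits and not only on which halogen the aryl group carries. The exchange of 4-iodophenyl for 2-fluorophenyl gives a 1.0-fold lower number from compound 1 to compound 4 (0.00 log units; within the scatter), which shows that two aryl groups with different halogens in different places can give numbers within the scatter of each other. Nothing available gives a reason for either step.

The compounds shown leave open how 4-fluorophenyl or unsubstituted phenyl would compare on this nitrogen, and so whether 3-fluorophenyl or 2-fluorophenyl is the exception. They also leave open whether a chlorophenyl or methoxyphenyl group would follow the same order.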